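This account rests on a few compounds, and the source may have more. Where it says the series, first, only, none or still open, it means among the compounds named here.

The series shares one core; compound 1 `COc1cc(-c2nnc(SCc3ccccc3[N+](=O)[O-])o2)ccc1O`, compound 2 `COc1cc(-c2nnc(SCc3ccc(F)cc3)o2)ccc1O` and compound 3 `COc1cc(-c2nnc(SCc3ccccc3Cl)o2)ccc1O` differ only in the group on the saturated chain carbon bound to a sulfur. In a functional assay on cells (T-cell, Mus musculus, strain BALB/c) for inhibition, read by MTT assay, with stated times of 24 h and 72 h (a higher number here means a weaker inhibitor, a lower number a stronger inhibitor), compound 1 gives 9600 nM, compound 2 gives 8190 nM and compound 3 gives 8430 nM, so compound 3 sits among three numbers that are all within the scatter of one another. Compound 4 `COc1cc(-c2nnc(SCc3ccccc3)o2)ccc1O` is reached by hydrogen in place of chloro on an aromatic carbon. For the measured compounds named here, two measured steps bear on this change: a 1.1-fold lower number from compound 1 to compound 3 (0.06 log units; within the scatter) and a 1.0-fold higher number from compound 2 to compound 3 (0.01 log units; within the scatter); neither rises above the scatter. Hence no step beyond the scatter is expected in this assay, and a 1.0-fold lower number from compound 3 to compound 4 (0.00 log units; within the scatter) is the estimated change. Compound 4 is expected to give 8400 nM in this assay, with a range from 4500 nM to 16000 nM.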

Compound 4, half-maximal inhibitory concentration: 1250 nM
Compound 4: the middle estimate sits 6.7-fold (0.83 log units) above what was measured, outside the stated range (below it).
By their numbers in this assay, from the lowest: compound 4; then compounds 2, 3 and 1 (each within the scatter of the next).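

Hydrogen on the aromatic ring separates compound 4 from all three substituted compounds in this assay (a 6.7-fold lower number from compound 3 to compound 4 (0.83 log units; beyond the scatter)) (a 6.6-fold lower number from compound 2 to compound 4 (0.82 log units; beyond the scatter)) (a 7.7-fold lower number from compound 1 to compound 4 (0.89 log units; beyond the scatter)). Chloro, fluoro and nitro did not separate from one another, so the earlier compounds gave no sign that this ring carbon could matter; here, the unsubstituted phenyl alone stands apart. Nothing shown gives a reason for this step. Still open, from the compounds shown here alone, is whether a methyl, methoxy or amine on the ring keeps the lower number or joins the substituted group.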